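This account rests on a few compounds, and the source may have more. Where it says the series, first, only, none or still open, it means among the compounds named here.

Compound 1 `C=CC(=O)NCc1ccc(C(=O)Nc2ccc(C)c(Nc3nccc(-c4cccnc4)n3)c2)cc1` — > 10000 nM in an ADME assay on BaF3 cells (Mus musculus) for cytotoxicity, read by CellTiter-Glo and CCK-8 assay, with a stated time of 72 h; on this read-out lower numbers stand for stronger inhibition of growth and higher numbers for weaker inhibition of growth.
Compound 2 `C=CC(=O)NCc1ccc(C(=O)Nc2ccc(C)c(Nc3nccc(-c4cccnc4)n3)c2)cc1C(F)(F)F` — > 10000 nM in this assay.

For compound 1 the value > 10000 nM is a limit of the assay and not a number. For compound 2 the value > 10000 nM is likewise a limit. Both sit at the limit of > 10000 nM in this assay, at which 2 of the 2 values shown sit, so the step that the two limits leave unreadable from compound 1 to compound 2 cannot be read. Compound 3 `Cc1ccc(NC(=O)c2ccc(CN(CCN(C)C)C(=O)CN(C)C)cc2)cc1Nc1nccc(-c2cccnc2)n1` is not yet measured; it differs from compound 1 by (2-(dimethylamino)ethyl)(((dimethylamino)methyl)carbonyl)amino in place of (vinylcarbonyl)amino on a saturated chain carbon bound to an aromatic carbon. Among the compounds with values here, no measured step bears on this change, and compound 1 shows only a limit, so the step expected is a step that the limit leaves unreadable from compound 1 to compound 3. Compound 3 is therefore estimated at 15000 nM, with a range from 4000 nM to 60000 nM.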

Compound 3, concentration for 50% growth inhibition: > 10000 nM
Compound 3 ended at the assay's limit; the forecaster's own chance of this, stated with the estimate: 80%; the middle value does not contradict the limit.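

Compound 1 and compound 3 both give limits and not numbers, so no step between them can be read: the limit of > 10000 nM in this assay, at which 3 of the 3 values shown sit.

The compounds shown leave open how strongly any of them inhibits growth, and whether either change affects it at all.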